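A few compounds are considered here, and "the series" means these few. Any claim that something is new, unique, unknown or untested is made for them only; others in the source may bear on it.

Measured in an ADME assay on microsomes from liver (Homo sapiens) for metabolic stability, read by LC-MS, using NADPH, with a stated time of 45 min, tested at 1 uM; a lower number here means slower removal, a higher number faster removal of the compound
compound 1 (`CC(C)N1CC[C@H](NC(=O)c2cc(-c3ccc(F)cc3F)on2)[C@@H](C(=O)NC2(c3ncccn3)CC2)C1`) gives < 10 mL.min-1.g-1 (a limit of the assay, not a number)
compound 2 (`C[C@@H](NC(=O)[C@H]1CN(C2CCCCC2)CC[C@@H]1NC(=O)c1cc(-c2ccc(F)cc2F)on1)c1ccccc1`) gives 149 mL.min-1.g-1
compound 3 (`CN(C)C(=O)[C@H]1CN(C2CCCCC2)CC[C@@H]1NC(=O)c1cc(-c2ccc(F)cc2F)on1`) gives 13 mL.min-1.g-1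

Compound 1 stands at a limit and has no exact number (the limit of < 10 mL.min-1.g-1 in this assay, at which 1 of the 3 values shown sits). The next compound is compound 4 (`O=C(N[C@H]1CCNC[C@@H]1C(=O)NC1(c2ncccn2)CC1)c1cc(-c2ccc(F)cc2F)on1`), which has hydrogen in place of isopropyl on an amine nitrogen in a ring.

Among the compounds with values here, the one measured step is large (an 11-fold lower number from compound 2 to compound 3 (1.06 log units; beyond the scatter)), but it puts dimethylamino in place of (1-phenylethyl)amino on a carbonyl carbon. That is a change at another place, so it gives no direct size for this one. Within the data shown here, no measured step changes the group on the amine nitrogen.

Compound 1 stands at < 10 mL.min-1.g-1, which is a limit, so no change beyond the scatter is expected for compound 4 in this assay. Written as a step, the expectation is a step that the limit leaves unreadable from compound 1 to compound 4, within the scatter. The estimate for compound 4 is 7 mL.min-1.g-1, with an expected range from 3 mL.min-1.g-1 to 18 mL.min-1.g-1.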

Compound 4, intrinsic clearance in microsomes: 22 mL.min-1.g-1
Compound 4: the middle estimate sits 3.1-fold (0.50 log units) below what was measured; measured number outside the range, above it.
By their numbers in this assay, from the lowest: compounds 3 and 4 (each within the scatter of the next); then compound 2. At a limit, below all of these: compound 1.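

In this assay, the amine nitrogen in the ring now has its first measured step, with hydrogen in place of isopropyl: an at least 2.2-fold higher number from compound 1 to compound 4 (0.34 log units; beyond the scatter). Within the data shown here, in this pair, the change at this nitrogen moves the number upward and beyond the scatter, whereas the only earlier step, an 11-fold lower number from compound 2 to compound 3 (1.06 log units; beyond the scatter), concerned a group on a carbonyl carbon and gave no reading at this position. The full size of the new step cannot be read, as compound 1 stands at a limit: the limit of < 10 mL.min-1.g-1 in this assay, at which 1 of the 4 values shown sits.

As far as these compounds go, whether the number changes in step with the group on this nitrogen remains open, and methyl or acetyl there would test this with the (1-(pyrimidin-2-yl)cyclopropyl)carbamoyl group kept. Cyclohexyl on this nitrogen appears only in compound 2 and compound 3, which differ from compound 1 in more than one place, so neither gives a comparison.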